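Moving the Chloro Group Around the Pendant Phenyl Ring

The source may hold more compounds than are shown below. What is called first, only, known or untested is meant among the compounds shown, and "the series" means these compounds.

Within the data shown here, compound 1 `Fc1ccc2c(c1)CCC(c1nnc(-c3cccc(Cl)c3)o1)O2` gives 84800 nM in a functional assay (on this read-out lower numbers stand for stronger inhibition and higher numbers for weaker inhibition), and stands level with compound 2 `Fc1ccc2c(c1)CCC(c1nnc(-c3ccccc3)o1)O2`, the only other compound measured, which gives 85900 nM; the step of a 1.0-fold higher number from compound 1 to compound 2 (0.01 log units; within the scatter) lies within the scatter. Compound 3 `Fc1ccc2c(c1)CCC(c1nnc(-c3ccc(Cl)cc3)o1)O2` differs from compound 1 by 4-chlorophenyl in place of 3-chlorophenyl on an aromatic carbon. Among the measured compounds shown here, the only measured step that bears on this change is the removal of the chloro group, a 1.0-fold higher number from compound 1 to compound 2 (0.01 log units; within the scatter), which left the read-out unchanged, so no step beyond the scatter is expected, a 1.0-fold higher number from compound 1 to compound 3 (0.00 log units; within the scatter). Compound 3 is therefore estimated at 85000 nM, between 40000 nM and 180000 nM.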

Compound 3, half-maximal inhibitory concentration: 85900 nM
Compound 3: the middle estimate sits 1.0-fold (0.00 log units) below what was measured; measured number inside the range.
By their numbers in this assay, from the lowest: compounds 1, 2 and 3 (each within the scatter of the next).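

In this assay the shift from 3-chlorophenyl to 4-chlorophenyl gives a 1.0-fold higher number from compound 1 to compound 3 (0.01 log units; within the scatter) and the addition of chloro to the bare phenyl at its new place gives no change at the digits printed from compound 2 to compound 3 (within the scatter) so the place of the chloro group on this phenyl ring, like its presence, moves the read-out by no more than the scatter across these three compounds. No measured evidence explains this flat result. On these data alone, whether an amine or a carboxylic acid on the pendant phenyl ring would move the read-out stays open, as does whether any change to the shared core would.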